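Swapping the sulfonyl aryl: from dimethylphenyl to bromopyridyl

The source may hold more compounds than are shown below. What is called first, only, known or untested is meant among the compounds shown, and "the series" means these compounds.

Compound 1 `CCc1ccc(S(=O)(=O)N2CCC(N3CCC(C)CC3)CC2)cc1` gives > 5000 nM in a functional assay on DLD-1 cells (Homo sapiens) for antiproliferative activity, read by CellTiter-Glo, with a stated time of 72 h (on this read-out lower numbers stand for stronger inhibition and higher numbers for weaker inhibition), which is a limit of the assay (the limit of > 5000 nM in this assay, at which 1 of the 3 values shown sits).
Compound 2 `CC1CCN(C2CCN(S(=O)(=O)c3ccc(F)cc3F)CC2)CC1` gives 102 nM in this assay.
Compound 3 `Cc1ccc(S(=O)(=O)N2CCC(N3CCC(C)CC3)CC2)cc1C` gives 24 nM in this assay.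

Compound 3 stands lowest of the two numbers given, with compound 2 nearest: a 4.3-fold lower number from compound 2 to compound 3 (0.63 log units; beyond the scatter). Compound 4 `CC1CCN(C2CCN(S(=O)(=O)c3cncc(Br)c3)CC2)CC1` differs from compound 3 at the same place: 5-bromopyridin-3-yl in place of 3,4-dimethylphenyl on a sulfonyl sulfur. For the measured compounds named here, the steps that bear on this change all sit on the sulfonyl sulfur: an at least 200-fold lower number from compound 1 to compound 3 (2.31 log units; beyond the scatter) and an at least 49-fold lower number from compound 1 to compound 2 (1.69 log units; beyond the scatter) show that the aryl group there moves the number strongly, and a 4.3-fold lower number from compound 2 to compound 3 (0.63 log units; beyond the scatter) shows a modest gap between two groups that both carry small substituents. No ring with a hetero atom has yet been measured here, so a modest rise is expected, a 6.3-fold higher number from compound 3 to compound 4 (0.80 log units; beyond the scatter), with wide uncertainty. Compound 4 is estimated at 150 nM, between 30 nM and 1500 nM.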

Compound 4, half-maximal inhibitory concentration: > 5000 nM
Compound 4: no number, only a limit; the forecaster's own chance of this, stated with the estimate: 15%; at least 33-fold (1.52 log units) between middle value and limit.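

In this assay compound 4 sits at a limit and not at a number: the limit of > 5000 nM in this assay, at which 2 of the 4 values shown sit.

Even so, 5-bromopyridin-3-yl gives an at least 200-fold higher number from compound 3 to compound 4 (2.31 log units; beyond the scatter) and an at least 49-fold higher number from compound 2 to compound 4 (1.69 log units; beyond the scatter), so 4-ethylphenyl is no longer the only group on the sulfonyl sulfur that ends at the limit. The step from compound 1 to compound 4 cannot be read, as both are limits.

Compound 4 brings in the ring nitrogen and the bromine together, so the shown compounds do not separate the two. Going by these compounds, whether pyridin-3-yl without bromine or 3-bromophenyl would stay near compound 3 remains open.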